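A second methyl on the amine nitrogen

The source may report more compounds than this note shows. Statements on the series, on what has been measured and on what is new or still open speak of the compounds shown alone.

Among the measured compounds shown here, in a functional assay on HCT-8 cells (Homo sapiens) for antiproliferative activity, read by MTT assay, with a stated time of 48 h (a higher number here means a weaker inhibitor, a lower number a stronger inhibitor), compound 1 `COc1ccc(C(=O)c2ccc(OC)c3c2C=CC(C)(C)O3)c(NC(=O)CN)c1` gives 1050 nM and compound 2 `CNCC(=O)Nc1cc(OC)ccc1C(=O)c1ccc(OC)c2c1C=CC(C)(C)O2` gives 3460 nM as the higher of the only two numbers so far, which makes it the weaker inhibitor of the pair. For the measured compounds named here, compound 3 `COc1ccc(C(=O)c2ccc(OC)c3c2C=CC(C)(C)O3)c(NC(=O)CN(C)C)c1` has not yet been measured and carries methyl in place of hydrogen on an amine nitrogen as its one structural change from compound 2, methyl in place of hydrogen on an amine nitrogen, so that methylamino becomes dimethylamino. One measured change bears on this, the same replacement made one nitrogen substituent earlier, and it gave a 3.3-fold higher number from compound 1 to compound 2 (0.52 log units; beyond the scatter) as a modest result. A single case cannot show whether a second methyl repeats the first, but the expectation in this assay follows that case, with a further rise towards weaker inhibition of similar or somewhat smaller size. The estimated change is a 1.6-fold higher number from compound 2 to compound 3 (0.20 log units; within the scatter) as the expected outcome. For compound 3 the expected value is 5500 nM with an estimated range from 2300 nM to 13000 nM as its likely span.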

Compound 3, half-maximal inhibitory concentration: 5660 nM
Compound 3: middle estimate off by 1.0-fold (0.01 log units), on the low side, and the stated range covers the measured number.
By their numbers in this assay, from the lowest: compound 1; then compounds 2 and 3 (each within the scatter of the next).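

In this assay, the second methyl on the amine nitrogen gives a 1.6-fold higher number from compound 2 to compound 3 (0.21 log units; within the scatter), which leaves compound 2 and compound 3 inseparable, whereas the first methyl had given a 3.3-fold higher number from compound 1 to compound 2 (0.52 log units; beyond the scatter), a step beyond the scatter. Read as one replacement of amino by dimethylamino on a saturated chain carbon bound to a carbonyl carbon, the change gives a 5.4-fold higher number from compound 1 to compound 3 (0.73 log units; beyond the scatter), so among these three compounds a clear separation exists only between compound 1, with its free amino group, and the two methylated compounds. Nothing shown here accounts for this outcome at the amine nitrogen.

What the three compounds leave open is whether the trend depends on methyl itself or would hold for ethyl or another larger alkyl group on the same nitrogen. They also leave open how a longer chain between the carbonyl and the amine, or a hydroxyl group or carboxylic acid in place of the amine, would read in this assay.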